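The source may hold more compounds than are shown below. What is called first, only, known or untested is meant among the compounds shown, and "the series" means these compounds.

Measured compounds in an ADME assay on Vero cells (Chlorocebus sabaeus) for cytotoxicity, read by MTT assay, with a stated time of 72 h; on this read-out lower numbers stand for higher toxicity in this test and higher numbers for lower toxicity in this test:
Compound 1 `C[C@]1(CN2CCc3nc(C4CCOCC4)ccc3C2)Cn2cc([N+](=O)[O-])nc2O1`: "not determined" (no result reported).
Compound 2 `C[C@]1(CN2CCc3nc(-c4cccc(F)c4)ccc3C2)Cn2cc([N+](=O)[O-])nc2O1`: > 32 ug/mL.

For compound 2 the entry in this assay is a limit of the assay, not a number; it sits at the limit of > 32 ug/mL in this assay, at which 1 of the 2 values shown sits. Compound 1 carries no result in this assay. Compound 2 thus stands as the only measured entry in the series, and only as a limit.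

Compound 3 `C[C@]1(CN2CCc3nc(-c4ccc(C(F)(F)F)cc4)ccc3C2)Cn2cc([N+](=O)[O-])nc2O1` remains to be measured in this assay. It differs from compound 2 by 4-(trifluoromethyl)phenyl in place of 3-fluorophenyl on an aromatic carbon. Going by the values given here, no step between measured compounds exists here, so no measured shift in this assay can be drawn on. For this change no shift beyond the scatter is expected in this assay, with the result likely again a limit. Compound 3 is expected near 40 ug/mL, within 16 ug/mL to 100 ug/mL, the expected step being a step that the limit leaves unreadable from compound 2 to compound 3.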

Compound 3, half-maximal cytotoxic concentration: > 32 ug/mL
Compound 3: a limit, no number (the forecaster's own chance of this, stated with the estimate: 75%); the middle value does not contradict the limit.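

In this assay, going by these compounds alone, no step between compound 2 and compound 3 can be read, as both entries are limits and not numbers: the limit of > 32 ug/mL in this assay, at which 2 of the 3 values shown sit. The compounds shown leave open where the actual cytotoxic concentration of either compound lies, and whether 4-(trifluoromethyl)phenyl in place of 3-fluorophenyl shifts it at all.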